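The compounds below may be only part of what the source reports. "The series", "measured", "known", "first", "only" and "open" are said of these compounds alone.

Among the measured compounds shown here, compound 3 `CC1CC(C(=O)N2CCc3nc(C#Cc4ccccc4)sc3C2)C1` is the only member of this small set to give a number in an assay on HEK293 cells for positive allosteric modulation of metabotropic glutamate receptor 5 (Homo sapiens), read by FLIPR, with a stated time of 1 h (a lower number here means that less compound is needed, a higher number that more compound is needed for the effect), where compound 3 gives 81 nM. Compound 1 `CC(C)CN1CCc2nc(C#Cc3ccccc3)sc2C1` reaches only the limit of this assay, > 10000 nM. Compound 2 `O=C(C1CC1)N1CCc2nc(C#Cc3ccccc3)sc2C1` likewise stops at the limit, > 10000 nM. The two steps that lead to compound 3 are both large: an at least 120-fold lower number from compound 1 to compound 3 (2.09 log units; beyond the scatter) and an at least 120-fold lower number from compound 2 to compound 3 (2.09 log units; beyond the scatter). The step between the two weaker compounds, a step that the two limits leave unreadable from compound 1 to compound 2, cannot be sized, a consequence of the limit of > 10000 nM in this assay, at which 2 of the 3 values shown sit.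

Compound 4 `O=C(C1CCCC1)N1CCc2nc(C#Cc3ccccc3)sc2C1` differs from compound 3 by cyclopentyl in place of 3-methylcyclobutyl on a carbonyl carbon. For the measured compounds named here, the measured step that bears on this change is the one from compound 2 to compound 3, where cyclopropyl was exchanged for 3-methylcyclobutyl on the same carbonyl carbon and the number fell at least as far as an at least 120-fold lower number from compound 2 to compound 3 (2.09 log units; beyond the scatter). The present change keeps the atom count and swaps one small carbocycle for another of the same size, so the step is expected to stay within the scatter. Compound 4 is therefore expected to give 100 nM, between 30 nM and 400 nM. That estimate corresponds to an expected step of a 1.2-fold higher number from compound 3 to compound 4 (0.09 log units; within the scatter).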

Compound 4, half-maximal effective concentration: 19 nM
Compound 4: middle estimate off by 5.3-fold (0.72 log units), on the high side, outside the stated range (below it).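

Cyclopentyl and 3-methylcyclobutyl have the same count of heavy atoms, all carbon, yet in this assay exchanging one for the other on the carbonyl carbon gives a 4.3-fold lower number from compound 3 to compound 4 (0.63 log units; beyond the scatter), so at this place the arrangement of these carbons counts and not their number alone. Measured against the two compounds at the limit, the change gives an at least 520-fold lower number from compound 2 to compound 4 (2.72 log units; beyond the scatter) and an at least 520-fold lower number from compound 1 to compound 4 (2.72 log units; beyond the scatter). Both of these steps are bounds rather than exact sizes: the limit of > 10000 nM in this assay, at which 2 of the 4 values shown sit.

The compounds shown leave open whether the trend continues with a larger ring on the carbonyl carbon, such as cyclohexyl, or holds for an open chain of carbons there. They also leave open how a ring containing oxygen, such as tetrahydropyranyl, or a cyclopentyl ring carrying a methyl or a fluorine would behave at this position.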